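Compound 1 and Compound 3 in a Cell Inhibition Assay

The compounds below may be only part of what the source reports. "The series", "measured", "known", "first", "only" and "open" are said of these compounds alone.

Compound 1, `COc1cc(/C=N/Nc2nc(-c3ccc(C(F)(F)F)cc3)cs2)c(Br)c(Br)c1OC`: > 100000 nM
Compound 2, `COc1cc(/C=N/Nc2nc(-c3cc(C(F)(F)F)cc(C(F)(F)F)c3)cs2)cc(Br)c1OC`: > 100000 nM

Of the compounds shown here, two have been measured so far in an ADME assay on HUVEC cells (Homo sapiens) for inhibition, read by MTT assay, with a stated time of 48 h; on this read-out higher numbers stand for weaker inhibition and lower numbers for stronger inhibition. Compound 1, `COc1cc(/C=N/Nc2nc(-c3ccc(C(F)(F)F)cc3)cs2)c(Br)c(Br)c1OC`, gives only a limit of the assay, > 100000 nM. Compound 2, `COc1cc(/C=N/Nc2nc(-c3cc(C(F)(F)F)cc(C(F)(F)F)c3)cs2)cc(Br)c1OC`, likewise gives only a limit, > 100000 nM. Compound 1 therefore stands at the same point as everything shown: the limit of > 100000 nM in this assay, at which 2 of the 2 values shown sit. Going by the values given here, no step between measured compounds can be drawn, as the two measured structures differ in more than one place, and no size of change has been seen.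

Compound 3, `COc1cc(/C=N/Nc2nc(-c3ccc(F)c(F)c3)cs2)c(Br)c(Br)c1OC`, is the structure not yet measured. It differs from compound 1 by 3,4-difluorophenyl in place of 4-(trifluoromethyl)phenyl on an aromatic carbon, in words 3,4-difluorophenyl in place of 4-(trifluoromethyl)phenyl on an aromatic carbon. Among the compounds with values here, with only limits available, no measured step sets a scale for this change, and the expectation is no movement beyond the scatter, most probably another limit. The expected step is a number no higher from compound 1 to compound 3 (the limit leaves the size open). Compound 3 is estimated at 100000 nM, with a range from 30000 nM to 300000 nM.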

Compound 3, half-maximal inhibitory concentration: 54700 nM
The estimate for compound 3 lay 1.8-fold (0.26 log units) above the measured number, within the range that was stated.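

In this assay, placing 3,4-difluorophenyl where 4-(trifluoromethyl)phenyl stood, on the aromatic carbon of the five-membered ring next to the ring nitrogen, gives an at least 1.8-fold lower number from compound 1 to compound 3 (0.26 log units; that floor lies within the scatter). Going by these compounds alone, compound 3 thus supplies the first true number, so this position can be changed with a readable result on the core of compound 1, but the step alone does not establish a real gain in inhibition, since its floor stays within the scatter and its upper size remains unknown. The other two compounds offer no number against which compound 3 could be set, and each of their values is only a limit: the limit of > 100000 nM in this assay, at which 2 of the 3 values shown sit.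

The compounds shown leave open how far the number from compound 3 truly lies from that of compound 1, and whether the change comes from losing the trifluoromethyl group or from gaining the two fluorines. They also leave open how an aryl ring bearing an amine or a carboxylic acid, or a plain phenyl group, would read at this same position.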